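Amide substituent changes on a shared core

The compounds below may be only part of what the source reports. "The series", "measured", "known", "first", "only" and "open" are said of these compounds alone.

Three amides of a shared core have been measured in a functional assay on A549 cells (Homo sapiens) for inhibition, read by MTT assay, with a stated time of 48 h; a higher number here means a weaker inhibitor, a lower number a stronger inhibitor. Compound 1 `C#CCNC(=O)/C=C/c1c(/C=C/c2ccc(OC)cc2)cc(OC)cc1OC` gives 6930 nM. Compound 2 `CCCCNC(=O)/C=C/c1c(/C=C/c2ccc(OC)cc2)cc(OC)cc1OC` gives 1880 nM, and a 3.7-fold lower number from compound 1 to compound 2 (0.57 log units; beyond the scatter). Compound 3 `CCCCN(CCCC)C(=O)/C=C/c1c(/C=C/c2ccc(OC)cc2)cc(OC)cc1OC` gives 6160 nM. Compound 3 therefore holds the second highest of the three numbers: its number and that of compound 1 lie within the scatter, as a 1.1-fold lower number from compound 1 to compound 3 (0.05 log units; within the scatter) shows, while a 3.3-fold higher number from compound 2 to compound 3 (0.52 log units; beyond the scatter) separates it from compound 2.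

Compound 4 `COc1ccc(/C=C/c2cc(OC)cc(OC)c2/C=C/C(=O)N2CCC(c3ccccc3)CC2)cc1` has not yet been measured. The change from compound 3 is 4-phenylpiperidin-1-yl in place of dibutylamino on a carbonyl carbon. Among the compounds with values here, both compound 3 and compound 4 carry two carbon substituents on the amide-type nitrogen, so the only measured step that bears on the change is a 3.3-fold higher number from compound 2 to compound 3 (0.52 log units; beyond the scatter), and no measured step exchanges one such pair of substituents for another. For compound 4 the expected step is a 1.2-fold lower number from compound 3 to compound 4 (0.09 log units; within the scatter), which need not exceed the scatter. Compound 4 is estimated at 5000 nM, within a range from 1800 nM to 14000 nM.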

Compound 4, half-maximal inhibitory concentration: 6690 nM
Estimate against measurement, compound 4: 1.3-fold (0.13 log units) below; the range from low to high includes it.
By their numbers in this assay, from the lowest: compound 2; then compounds 3, 4 and 1 (each within the scatter of the next).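

Notes on the amide nitrogen: in this assay, the ring-bearing 4-phenylpiperidin-1-yl on the carbonyl carbon reads the same as open-chain dibutylamino (a 1.1-fold higher number from compound 3 to compound 4 (0.04 log units; within the scatter)), so this exchange of two nitrogen substituents for a ring leaves the number unmoved. Compound 4 joins compound 3 in standing apart from the butylamino amide (a 3.6-fold higher number from compound 2 to compound 4 (0.55 log units; beyond the scatter)), so neither amide lacking the amide hydrogen matches compound 2, but this does not make the amide hydrogen sufficient: compound 1 carries it and still reads with compound 4 (a 1.0-fold lower number from compound 1 to compound 4 (0.02 log units; within the scatter)). No measurement here gives a reason for these steps.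

Still open, on these data alone, is whether an unsubstituted piperidine or a morpholine ring would also read with compound 3 and compound 4. It is also unknown whether a hexyl chain on the secondary amide would extend the advantage of compound 2.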